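A few compounds are considered here, and "the series" means these few. Any claim that something is new, unique, unknown or untested is made for them only; others in the source may bear on it.

Measured compounds in this series:
compound 1 `Cc1cc(=O)n(-c2ccc(F)cc2)nc1C(=O)Nc1ccc(Oc2ncnc3[nH]ccc23)cc1`; in a functional assay on PC-3 cells (Homo sapiens) for cytotoxicity, read by MTT assay, with a stated time of 72 h (a lower number here means a stronger inhibitor, a higher number a weaker inhibitor), compound 1 reaches only the assay limit > 60000 nM, which is a limit and not a number.
compound 2 `Cc1cc(=O)n(-c2ccc(F)cc2)nc1C(=O)Nc1ccc(Oc2ncnc3[nH]ccc23)c(F)c1`; in this assay compound 2 gives 17300 nM.

Compound 2 carries the only number shown; the other value is the limit (the limit of > 60000 nM in this assay, at which 1 of the 2 values shown sits). Among the compounds with values here, the single measured step, an at least 3.4-fold lower number from compound 1 to compound 2 (0.54 log units; beyond the scatter), concerns an aromatic carbon elsewhere in the molecule and leaves the group on the aromatic nitrogen untouched.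

Compound 3 `Cc1cc(=O)n(-c2ccc(Br)cc2F)nc1C(=O)Nc1ccc(Oc2ncnc3[nH]ccc23)c(F)c1` differs from compound 2 by 4-bromo-2-fluorophenyl in place of 4-fluorophenyl on an aromatic nitrogen. No measured pair varies this group, so the shown data give neither direction nor size for the change. The step from compound 2 to compound 3 is therefore expected to stay within the scatter, a 1.2-fold lower number from compound 2 to compound 3 (0.09 log units; within the scatter). For compound 3 the estimated value in this assay is 14000 nM, with a range from 4500 nM to 45000 nM.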

Compound 3, half-maximal inhibitory concentration: 13300 nM
Beside the measured number, compound 3's estimate is 1.1-fold (0.02 log units) above it, and the stated range covers the measured number.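

Within the data shown here, the first measured change of the group on the aromatic nitrogen gives a 1.3-fold lower number from compound 2 to compound 3 (0.11 log units; within the scatter) in this assay. Among these compounds, at this position, then, 4-bromo-2-fluorophenyl and 4-fluorophenyl are not told apart, and the fluoro step on the other aromatic ring remains the only step beyond the scatter. Compound 1 remains the one entry that is a limit and not a number: the limit of > 60000 nM in this assay, at which 1 of the 3 values shown sits.

From the compounds shown here alone, both groups compared on the aromatic nitrogen are halogen-bearing phenyl rings, so it stays open whether an amine, a carboxylic acid or a plain alkyl chain there would move the number beyond the scatter. Going by these compounds, the bromine and the second fluorine also enter together in a single step, so the contribution of each alone stays open.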